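A few compounds are considered here, and "the series" means these few. Any claim that something is new, unique, unknown or untested is made for them only; others in the source may bear on it.

Compound 3 `C#CCCC(=O)CC1CCN(C2CCN(S(=O)(=O)c3c(C)cc(C)cc3C)CC2)CC1` gives 3 nM in a functional assay on DLD-1 cells (Homo sapiens) for antiproliferative activity, read by CellTiter-Glo, with a stated time of 72 h (on this read-out lower numbers stand for stronger inhibition and higher numbers for weaker inhibition), the highest of the two numbers, standing apart from compound 2 `Cc1cc(C)c(S(=O)(=O)N2CCC(N3CCC(C(C)C)CC3)CC2)c(C)c1` at 0.3 nM by a 10-fold higher number from compound 2 to compound 3 (1.00 log units; beyond the scatter). Compound 1 `Cc1cc(C)c(S(=O)(=O)N2CCC(N3CCC(CCC#N)CC3)CC2)c(C)c1` shows only a limit, > 5000 nM (the limit of > 5000 nM in this assay, at which 1 of the 3 values shown sits). Compound 4 `Cc1cc(C)c(S(=O)(=O)N2CCC(N3CCC(O)CC3)CC2)c(C)c1` carries hydroxy in place of ((but-3-yn-1-yl)carbonyl)methyl on a saturated ring carbon. Among the measured compounds shown here, the steps that bear on this are an at least 1600-fold lower number from compound 1 to compound 3 (3.22 log units; beyond the scatter) and an at least 16000-fold lower number from compound 1 to compound 2 (4.22 log units; beyond the scatter), each seen when a small group at this carbon gave way to a larger one. Here the larger group leaves and a single small group enters, so a large rise in the number in this assay is expected, possibly reaching a limit. Compound 4 is therefore estimated at 3000 nM, with a range of 300 nM to 20000 nM. That expected step is a 1000-fold higher number from compound 3 to compound 4 (3.00 log units; beyond the scatter).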

Compound 4, half-maximal inhibitory concentration: 106 nM
The estimate for compound 4 lay 28-fold (1.45 log units) above the measured number; measured number below the stated range.
By their numbers in this assay, from the lowest: compound 2; then compound 3; then compound 4. At a limit, above all of these: compound 1.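

In this assay, replacing either larger group with hydroxy on this saturated ring carbon costs much, giving a 35-fold higher number from compound 3 to compound 4 (1.55 log units; beyond the scatter) and a 350-fold higher number from compound 2 to compound 4 (2.55 log units; beyond the scatter). Yet group size alone does not order these compounds, since hydroxy, with 1 heavy atom, still gives an at least 47-fold lower number from compound 1 to compound 4 (1.67 log units; beyond the scatter). The value of compound 1 is a limit and not a number: the limit of > 5000 nM in this assay, at which 1 of the 4 values shown sits.

From the compounds shown here alone, whether an amine, a methoxy group or a carboxylic acid at this carbon would fall nearer compound 4 or compound 2 stays open. So does whether a nitrile on a shorter chain would give a number as high as that of compound 1.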